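The compounds below may be only part of what the source reports. "The series", "measured", "known", "first", "only" and "open" are said of these compounds alone.

Measured so far:
compound 1, `CC(C)CC/N=C(\NC#N)Nc1cccnc1`: 20 mg/kg
compound 2, `CC1(/N=C(\NC#N)Nc2cccnc2)CCC1`: 50 mg/kg

The account concerns a functional assay on the whole organism (blood, strain Wistar-Okamoto) with Rattus norvegicus as the target, with a stated time of 5 days (a lower number here means that less compound is needed, a higher number that more compound is needed for the effect), and two compounds measured in it. Compound 1 gives 20 mg/kg in this assay, and compound 2, which carries 1-methylcyclobutyl in place of isopentyl on a double-bonded nitrogen, gives 50 mg/kg. For the measured compounds named here, that single change produced a 2.5-fold higher number from compound 1 to compound 2 (0.40 log units; beyond the scatter), so compound 2 stands at the higher of the two numbers, with compound 1 as its only neighbour.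

Compound 3, `C=C(C)C/N=C(\NC#N)Nc1cccnc1`, has not yet been measured in this assay. Going by the values given here, it differs from compound 2 in one place: 2-methylprop-2-en-1-yl in place of 1-methylcyclobutyl on a double-bonded nitrogen The only step that bears on this change is the one from compound 1 to compound 2, in which the 1-methylcyclobutyl group raised the number modestly. Since compound 3 replaces that group with a chain that has no ring, a return toward the number of compound 1 is expected, that is, a modest step downward in this assay, a 2.0-fold lower number from compound 2 to compound 3 (0.30 log units; within the scatter). Compound 3 is therefore estimated at 25 mg/kg, with a likely range from 10 mg/kg to 60 mg/kg.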

Compound 3, minimum effective dose: 20 mg/kg
For compound 3 the middle estimate is 1.3-fold (0.10 log units) above the measured one; measured number inside the range.
By their numbers in this assay, from the lowest: compounds 1 and 3 (each within the scatter of the next); then compound 2.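

In this assay, leaving the ring for the open chain 2-methylprop-2-en-1-yl on the double-bonded nitrogen gives a 2.5-fold lower number from compound 2 to compound 3 (0.40 log units; beyond the scatter), so the higher number of compound 2 does not carry over to this ring-free group. The second comparison, with 1-methylethenyl in place of isobutyl on the saturated chain carbon bound to the double-bonded nitrogen, gives no change at the digits printed from compound 1 to compound 3 (within the scatter): the open chains with and without a double bond cannot be told apart here, and compound 2 alone stands apart from both. No measurement shown here explains why the 1-methylcyclobutyl compound differs from the two open-chain compounds.

Compound 2 is the only compound with a ring at this place, so the shown results cannot say whether the difference goes with the ring itself or with the methyl-bearing ring carbon on the nitrogen. As far as these compounds go, how a tert-butyl group, an unsubstituted cyclobutyl ring or a longer chain would compare in this assay remains open.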